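Furan-2-yl in place of 4-bromophenyl on a carbonyl carbon

The source may hold more compounds than are shown below. What is called first, only, known or untested is meant among the compounds shown, and "the series" means these compounds.

Compound 1 `COc1ccc(/C=C/C(=O)c2ccc(OC)c3c2OC(C)(C)C=C3)cc1OCCO` gives 9600 nM in a functional assay on A-375 cells (Homo sapiens) for cytotoxicity, read by MTT assay; a lower number here means a stronger inhibitor, a higher number a weaker inhibitor
Compound 2 `COc1ccc(/C=C/C(=O)c2ccc(OC)c3c2OC(C)(C)C=C3)cc1OC(=O)c1ccc(Br)cc1` gives 420 nM in this assay

Compound 2 holds the lower of these two numbers in this assay by a margin beyond the scatter. Compound 3 `COc1ccc(/C=C/C(=O)c2ccc(OC)c3c2OC(C)(C)C=C3)cc1OC(=O)c1ccco1` carries furan-2-yl in place of 4-bromophenyl on a carbonyl carbon, the change in full being furan-2-yl in place of 4-bromophenyl on a carbonyl carbon on the shared core. Among the measured compounds shown here, the one measured step, a 23-fold lower number from compound 1 to compound 2 (1.36 log units; beyond the scatter), brought in (4-bromophenyl)carbonyl in place of 2-hydroxyethyl, and compound 3 keeps the carbonyl. For the measured compounds named here, no measured step swaps the group on that carbonyl carbon alone. A far smaller step is expected, towards a higher number, with a 2.1-fold higher number from compound 2 to compound 3 (0.33 log units; beyond the scatter) as the estimate. Compound 3 is estimated at 900 nM, with 300 nM to 2800 nM as its expected range.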

Compound 3, half-maximal inhibitory concentration: 680 nM
The estimate for compound 3 lay 1.3-fold (0.12 log units) above the measured number, within the range that was stated.
By their numbers in this assay, from the lowest: compounds 2 and 3 (each within the scatter of the next); then compound 1.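

In this assay, furan-2-yl on the carbonyl carbon, in place of 4-bromophenyl, gives a 1.6-fold higher number from compound 2 to compound 3 (0.21 log units; within the scatter), so this assay does not separate the two rings. With a 14-fold lower number from compound 1 to compound 3 (1.15 log units; beyond the scatter), the large change from 2-hydroxyethyl also appears with the furan-2-yl ester, so it does not require the 4-bromophenyl group. No evidence is available to explain either result. The compounds shown leave open whether the carbonyl carbon would tolerate a non-aromatic group, such as a longer alkyl chain or an amine. They also leave open whether the ester oxygen could be replaced by an amide nitrogen.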